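Para-substituent on the ketone aryl ring: methyl to ethyl

The compounds below may be only part of what the source reports. "The series", "measured", "known", "first", "only" and "open" are said of these compounds alone.

Compounds measured so far in a functional assay on HCT-116 cells (Homo sapiens) for cytotoxicity, read by MTT assay, with a stated time of 48 h; a lower number here means a stronger inhibitor, a higher number a weaker inhibitor:
compound 1 `O=C(/C=C/c1ccc2c(c1)B(O)OC2)c1ccc(F)cc1`: 2800 nM
compound 2 `O=C(/C=C/c1ccc2c(c1)B(O)OC2)c1ccc(I)cc1`: 11600 nM
compound 3 `Cc1ccc(C(=O)/C=C/c2ccc3c(c2)B(O)OC3)cc1`: 10500 nM

Compound 3 stands second highest of the three numbers; its step to compound 2 lies within the scatter, and the step of a 3.8-fold higher number from compound 1 to compound 3 (0.57 log units; beyond the scatter), like a 4.1-fold higher number from compound 1 to compound 2 (0.62 log units; beyond the scatter), is modest but beyond it. Compound 4 `CCc1ccc(C(=O)/C=C/c2ccc3c(c2)B(O)OC3)cc1` differs from compound 3 by methyl in place of hydrogen on a saturated chain carbon bound to an aromatic carbon. Going by the values given here, no measured step covers a change at a saturated chain carbon, and the pair a 1.1-fold lower number from compound 2 to compound 3 (0.04 log units; within the scatter) shows that exchanging one group for another at this position need not move the number at all. Compound 4 is therefore expected to show no step beyond the scatter, a 1.1-fold higher number from compound 3 to compound 4 (0.06 log units; within the scatter). The estimate for compound 4 is 12000 nM, in the range 5000 nM to 30000 nM.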

Compound 4, half-maximal inhibitory concentration: 10900 nM
Compound 4: the middle estimate sits 1.1-fold (0.04 log units) above what was measured, within the range that was stated.
By their numbers in this assay, from the lowest: compound 1; then compounds 3, 4 and 2 (each within the scatter of the next).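

In this assay methyl to ethyl, the only change at a saturated chain carbon shown, gives a 1.0-fold higher number from compound 3 to compound 4 (0.02 log units; within the scatter) and leaves the number in place. Ethyl in place of iodo gives a 1.1-fold lower number from compound 2 to compound 4 (0.03 log units; within the scatter) while ethyl in place of fluoro gives a 3.9-fold higher number from compound 1 to compound 4 (0.59 log units; beyond the scatter) and so compound 1 alone stands apart from the other three. Nothing given here accounts for these steps.

From the compounds shown here alone, whether a longer chain would also leave the number in place remains open. So does whether an amine or a carboxylic acid here would bring it towards that of compound 1.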